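The source may report more compounds than this note shows. Statements on the series, on what has been measured and on what is new or still open speak of the compounds shown alone.

Compound 1 `O=[N+]([O-])c1cn2c(n1)OC[C@@H](OC/C=C/c1ccc(-c3ccc(OC(F)(F)F)cc3)cc1)C2` and compound 2 `O=[N+]([O-])c1cn2c(n1)OC[C@@H](OC/C=C/c1ccc(OCc3ccccc3)cc1)C2` share one core and differ in a single place: benzyloxy in place of 4-(trifluoromethoxy)phenyl on an aromatic carbon. In a physicochemical assay for solubility, read by HPLC, at pH 7 (a higher number here means a more soluble compound, a lower number a less soluble compound), compound 1 gives 0.5 ug/mL, while compound 2 gives 0.06 ug/mL, so that an 8.3-fold lower number from compound 1 to compound 2 (0.92 log units; beyond the scatter). Compound 3 `O=[N+]([O-])c1cn2c(n1)OC[C@@H](OCCCc1ccc(-c3ccc(OC(F)(F)F)cc3)cc1)C2` carries the same 4-(trifluoromethoxy)phenyl group on another core; the difference between its core and that of compound 1 is not broken down here. In this assay compound 3 gives 1.7 ug/mL, the highest of the three numbers. Compound 4 `O=[N+]([O-])c1cn2c(n1)OC[C@@H](OCCCc1ccc(OCc3ccccc3)cc1)C2` has not yet been measured. It stands to compound 3 as compound 2 stands to compound 1, since (benzyloxy in place of 4-(trifluoromethoxy)phenyl on an aromatic carbon), and the surroundings of the place are described in the same words for both pairs, so the change is taken as the same kind of change. For the measured compounds named here, the one earlier instance moved the number down by a modest step, and that step is the only guide here. Because compound 3 gives 1.7 ug/mL, a step of similar size is expected, an 8.5-fold lower number from compound 3 to compound 4 (0.93 log units; beyond the scatter). Compound 4 is therefore estimated at 0.2 ug/mL, within a range from 0.07 ug/mL to 0.6 ug/mL.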

Compound 4, solubility: 3.8 ug/mL
Estimate against measurement, compound 4: 19-fold (1.28 log units) below; the measured number lies above the stated range.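

In this assay the exchange of 4-(trifluoromethoxy)phenyl for benzyloxy gives a 2.2-fold higher number from compound 3 to compound 4 (0.35 log units; beyond the scatter) while on the core of compound 1 it gave an 8.3-fold lower number from compound 1 to compound 2 (0.92 log units; beyond the scatter) so the two steps run in opposite directions and the change did not carry over from one core to the other. For the compounds shown here, this rests on two pairs only: it shows that the step on one core was no guide to the step on the other here, but it does not show how the exchange behaves on any further core, or which of the two steps would be the more usual one. Nothing shown accounts for the difference between the two cores.

The compounds shown leave open what the same exchange does on a core carrying a longer chain. They also leave open what an amine or a carboxylic acid would give in place of either group, on either core.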